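Trifluoromethyl for Methyl on a Second Core

The source may hold more compounds than are shown below. What is called first, only, known or untested is meant among the compounds shown, and "the series" means these compounds.

Compound 1 `CC(=O)c1ccc(OCc2ccc(C)cc2)cc1` and compound 2 `CC(=O)c1ccc(OCc2ccc(C(F)(F)F)cc2)cc1` share one core, while compound 3 `CC(=O)c1cccc(OCc2cccc(C)c2)c1` and compound 4 `CC(=O)c1cccc(OCc2cccc(C(F)(F)F)c2)c1` share another. The two cores hold the same atoms joined differently, and the difference between them is not broken down here. In an assay on isolated protein for inhibition of Amine oxidase [flavin-containing] A (Homo sapiens), read by Amplex Red, with a stated time of 15 min, tested at 100 uM (a lower number here means less inhibition, a higher number more inhibition at the concentration tested (going by the name of the read-out)), compound 1 gives 5.96%. In this assay compound 2 gives 26.4% and compound 3 gives 31.1%. Compound 3 and compound 2 lie within the scatter of each other. The change trifluoromethyl in place of methyl on an aromatic carbon produced the step of a number 20.4 percentage points higher from compound 1 to compound 2 (beyond the scatter). The change planned on the second core, (trifluoromethyl in place of methyl on an aromatic carbon), is the same kind of change, not the same one: in the first pair the group sits para to a large group, in the second pair meta to a large group. For compound 4 the step of a number 13.9 percentage points higher from compound 3 to compound 4 (beyond the scatter) is expected in this assay; this expectation rests on the step of a number 20.4 percentage points higher from compound 1 to compound 2 (beyond the scatter), with the differing place of the group leaving the size less certain. Compound 4 is accordingly estimated at 45%, between 28% and 62%.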

Compound 4, a percentage reported as inhibition, at one concentration (the size of the read-out at that concentration, not a potency): 46.7%
Beside the measured number, compound 4's estimate is 1.7 percentage points below it; measured number inside the range.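

In this assay, trifluoromethyl in place of methyl on an aromatic carbon gave a number 15.6 percentage points higher from compound 3 to compound 4 (beyond the scatter), so the change raised the read-out on the second core as it had on the first. Among the compounds shown here, the size of the rise also held across the two cores, as far as these pairs can tell: the same change on two cores in this assay, a number 20.4 percentage points higher (beyond the scatter) from compound 1 to compound 2 and a number 15.6 percentage points higher (beyond the scatter) from compound 3 to compound 4, 4.8 percentage points apart, within the scatter of two such steps This rests on only one pair per core, read at a single concentration and not as a potency, and the group's place differs between the pairs, so it shows neither that the step would hold on a further core nor what the core and the place each contribute.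

The compounds shown leave open whether the step belongs to trifluoromethyl in particular or would also appear with another group on that carbon, such as a nitrile, an amine, a carboxylic acid or a longer chain. They also leave open what trifluoromethyl in place of methyl would do with the group's place swapped between the two cores.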